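Homologated benzyl amine in the piperidine series

The source may report more compounds than this note shows. Statements on the series, on what has been measured and on what is new or still open speak of the compounds shown alone.

The compounds share a core carrying a triazolyl indole joined through a propyl chain to a piperidine, and differ in the amine group on that ring. In an assay on CHO cells for displacement of a labelled ligand from 5-hydroxytryptamine receptor 1D (Homo sapiens) (on this read-out lower numbers stand for stronger inhibition and higher numbers for weaker inhibition), compound 1 `CN(Cc1cccs1)C1CCN(CCCc2c[nH]c3ccc(-n4cnnc4)cc23)CC1` gives 4.3 nM. Compound 2 `CC(=O)Nc1ccc([C@H](C)NCC2CCN(CCCc3c[nH]c4ccc(-n5cnnc5)cc34)CC2)cc1` gives 0.6 nM in this assay, and compound 3 `CN(Cc1ccc(S(C)(=O)=O)cc1)C1CCN(CCCc2c[nH]c3ccc(-n4cnnc4)cc23)CC1` gives 18 nM. Compound 1 thus stands second highest of the three numbers, nearer to compound 3 than to compound 2.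

Compound 4 `CN(Cc1ccccc1)CC1CCN(CCCc2c[nH]c3ccc(-n4cnnc4)cc23)CC1` has not been measured. It differs from compound 1 in that ((benzyl(methyl)amino)methyl in place of methyl((thiophen-2-yl)methyl)amino on a saturated ring carbon). For the measured compounds named here, the only measured step at a related position is a 4.2-fold higher number from compound 1 to compound 3 (0.62 log units; beyond the scatter), where a substituted phenyl group replaced the thiophene and the number moved modestly upward. Compound 2, which also carries a methylene spacer on the ring carbon and an aryl-bearing amine, shows a low number. A plain benzyl group is expected to be closer to the thiophene case than to the sulfonyl case, so the step of a 1.1-fold lower number from compound 1 to compound 4 (0.03 log units; within the scatter) is expected to stay within the scatter. Compound 4 is therefore estimated at 4 nM, with a range from 1.2 nM to 14 nM.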

Compound 4, half-maximal inhibitory concentration: 0.9 nM
Compound 4: the middle estimate sits 4.4-fold (0.65 log units) above what was measured; the measured number lies below the stated range.
By their numbers in this assay, from the lowest: compounds 2 and 4 (each within the scatter of the next); then compound 1; then compound 3.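

In this assay, for the compounds shown here, (benzyl(methyl)amino)methyl in place of methyl((thiophen-2-yl)methyl)amino on a saturated ring carbon gives a 4.8-fold lower number from compound 1 to compound 4 (0.68 log units; beyond the scatter), so a change at this position can lower the number, whereas the only earlier step, a 4.2-fold higher number from compound 1 to compound 3 (0.62 log units; beyond the scatter), raised it. This step combines two changes, as the five-membered aromatic ring with a hetero atom gives way to a six-membered aromatic ring of carbon only and the amine now reaches the ring carbon through a methylene, so the drop cannot be assigned to either one alone. No measurement at hand accounts for the drop.

The compounds shown leave open how the thiophen-2-yl group would read on the methylene-extended amine. They also leave open how a pyridine ring in place of the phenyl ring, or an ethyl chain in place of the methylene, would read.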